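Working notes: from compound 3 to the amino compound 4

The source may report more compounds than this note shows. Statements on the series, on what has been measured and on what is new or still open speak of the compounds shown alone.

Measured in an ADME assay on microsomes from liver (Mus musculus) for metabolic stability, read by LC-MS, using NADPH, with a stated time of 30 min, tested at 0.1 uM; on this read-out lower numbers stand for a less stable compound and higher numbers for a more stable compound:
- compound 1 `O=S(=O)(c1cccc(-c2ccc3nccc(-c4ccncc4)c3n2)c1)N1CCC(O)CC1`: 7%
- compound 2 `CS(=O)(=O)Nc1cccc(-c2ccc3nccc(-c4ccncc4)c3n2)c1`: 50%
- compound 3 `C[C@@H]1CN(S(=O)(=O)c2cccc(-c3ccc4nccc(-c5ccncc5)c4n3)c2)C[C@H](C)N1`: 33%

Compound 3 stands second of the three values, under compound 2 and over compound 1. Compound 4 `Nc1cccc(-c2ccc3nccc(-c4ccncc4)c3n2)c1` has amino in place of (3,5-dimethylpiperazin-1-yl)sulfonyl on an aromatic carbon. The closest evidence is the modest a number 17 percentage points lower from compound 2 to compound 3 (beyond the scatter), which concerns the same aromatic carbon. The large a number 43 percentage points higher from compound 1 to compound 2 (beyond the scatter) concerns that carbon too. The modest a number 26 percentage points higher from compound 1 to compound 3 (beyond the scatter) shows that the group on the sulfonyl sulfur also shifts the number. Among the compounds with values here, no measured compound carries amino, so a modest rise in this assay is expected rather than a large one. The expected step is a number 12 percentage points higher from compound 3 to compound 4 (beyond the scatter). For compound 4 the estimate is 45%, with an expected range of 20% to 72%.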

Compound 4, percent of the compound remaining: 54%
For compound 4 the middle estimate is 9 percentage points below the measured one, within the range that was stated.
By their numbers in this assay, from the lowest: compound 1; then compound 3; then compounds 2 and 4 (each within the scatter of the next).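

In this assay, a bare amino group on this aromatic carbon is enough to carry the number well beyond both ring-bearing sulfonyl groups (a number 21 percentage points higher from compound 3 to compound 4 (beyond the scatter); a number 47 percentage points higher from compound 1 to compound 4 (beyond the scatter)). Hydrogen and methylsulfonyl on the aromatic nitrogen cannot be told apart here (a number 4 percentage points higher from compound 2 to compound 4 (within the scatter)), so the methylsulfonyl adds nothing measurable to this read-out. Nothing measured on these compounds explains these steps.

From the compounds shown here alone, whether an acetyl group or a methyl group on that nitrogen would hold the number stays open. So does whether a carboxylic acid on the same aromatic carbon would do so.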